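The source may hold more compounds than are shown below. What is called first, only, known or untested is meant among the compounds shown, and "the series" means these compounds.

Working notes on a series that shares one core and varies the aryl group on an aromatic nitrogen. Within the data shown here, compound 1 (`CC1(C)[C@H]2CC[C@]1(C)N(Cc1cn(-c3ccc(C#N)cc3)nn1)C(=O)C2`) gives 380 nM in a functional assay on OVCAR-3 cells (Homo sapiens) for inhibition, read by MTT assay, with a stated time of 24 h (a higher number here means a weaker inhibitor, a lower number a stronger inhibitor), and holds the higher number so far. Compound 2 (`CC1(C)[C@H]2CC[C@]1(C)N(Cc1cn(-c3ccccc3O)nn1)C(=O)C2`) gives 90 nM in this assay and holds the lowest of the two numbers, which makes it the stronger inhibitor of the pair.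

Compound 3 (`CC1(C)[C@H]2CC[C@]1(C)N(Cc1cn(-c3ccc(Cl)cc3)nn1)C(=O)C2`) is next, with 4-chlorophenyl in place of 2-hydroxyphenyl on an aromatic nitrogen. Among the measured compounds shown here, only one measured step bears on this change, and only in part. The 2-hydroxyphenyl of compound 2 is tied to the lower number in the modest step of a 4.2-fold lower number from compound 1 to compound 2 (0.63 log units; beyond the scatter) and compound 3 gives that group up, as compound 1 does. A step of similar or smaller size towards a higher number is therefore expected in this assay although a single pair with a different group is thin support. The expected move is a 2.8-fold higher number from compound 2 to compound 3 (0.44 log units; beyond the scatter) on this estimate. For compound 3 the estimated value is 250 nM with an expected range from 90 nM to 700 nM overall.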

Compound 3, half-maximal inhibitory concentration: 160 nM
Compound 3: middle estimate off by 1.6-fold (0.19 log units), on the high side; the range from low to high includes it.
By their numbers in this assay, from the lowest: compounds 2 and 3 (each within the scatter of the next); then compound 1.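

In this assay, replacing 2-hydroxyphenyl with 4-chlorophenyl gives a 1.8-fold higher number from compound 2 to compound 3 (0.25 log units; within the scatter), so the hydrogen-bond donor and acceptor counted on 2-hydroxyphenyl are not needed for a value in this range, since 4-chlorophenyl has neither. The comparison with compound 1 isolates a different change, chloro in place of cyano on an aromatic carbon, which gives a 2.4-fold lower number from compound 1 to compound 3 (0.38 log units; beyond the scatter); the higher number of compound 1 therefore cannot be read simply as the loss of 2-hydroxyphenyl, and among these three compounds it is 4-cyanophenyl that stands apart. No measurement at hand accounts for either step.

The compounds shown leave open whether unsubstituted phenyl would match 2-hydroxyphenyl and 4-chlorophenyl, and whether 2-chlorophenyl or 4-hydroxyphenyl would give similar numbers, which would help separate the identity of the group from where it sits on the aryl ring. Among these compounds, also open is how this aryl position would respond to an amine, a carboxylic acid or a longer chain, since only three aryl groups on the shared core can be compared here.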